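This account rests on a few compounds, and the source may have more. Where it says the series, first, only, none or still open, it means among the compounds named here.

For the measured compounds named here, compound 2 `Cc1cc(C)c(NC(=O)N(Cc2ccc(-c3cccnc3)cc2)C2CCCCCC2)c(C)c1` is the weaker of the two measured members: in an assay on microsomes from intestine for inhibition of acyl-CoA:cholesterol acyltransferase (Oryctolagus cuniculus) (on this read-out higher numbers stand for weaker inhibition and lower numbers for stronger inhibition), compound 2 gives 130 nM, and it holds the highest number of the two values shown. Going by the values given here, its nearest neighbour is compound 1 `Cc1cc(C)c(NC(=O)N(Cc2ccc(-c3ccccn3)cc2)C2CCCCCC2)c(C)c1`, which in this assay gives 33 nM; the one measured step, a 3.9-fold higher number from compound 1 to compound 2 (0.60 log units; beyond the scatter), describes the exchange of the six-membered ring attached to the core.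

Compound 3 `Cc1cc(C)c(NC(=O)N(Cc2ccc(-c3cc[nH]n3)cc2)C2CCCCCC2)c(C)c1` is not yet measured. It differs from compound 2 in that same place: 1H-pyrazol-3-yl in place of pyridin-3-yl on an aromatic carbon. The change sits on an aromatic carbon of a six-membered aromatic ring of carbon only, para to a large group.

Among the compounds with values here, no measured step exchanges a six-membered ring for a five-membered one, so the only guide is the step from compound 1 to compound 2, which shows that this position answers to the choice of ring. Compound 3 is therefore expected to fall somewhere between the two measured numbers, with a 1.6-fold lower number from compound 2 to compound 3 (0.21 log units; within the scatter) as the estimated step. On that basis compound 3 is estimated at 80 nM, within a range from 20 nM to 320 nM.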

Compound 3, half-maximal inhibitory concentration: 52 nM
For compound 3 the middle estimate is 1.5-fold (0.19 log units) above the measured one; the range from low to high includes it.
By their numbers in this assay, from the lowest: compounds 1 and 3 (each within the scatter of the next); then compound 2.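

The exchange of pyridin-3-yl for 1H-pyrazol-3-yl gives a 2.5-fold lower number from compound 2 to compound 3 (0.40 log units; beyond the scatter) in this assay, so this place on the six-membered aromatic ring of carbon only accepts a five-membered aromatic ring carrying a hydrogen-bond donor, and a six-membered ring is not needed there. Set against pyridin-2-yl, the same ring gives a 1.6-fold higher number from compound 1 to compound 3 (0.20 log units; within the scatter), which leaves compound 2 as the weakest of the three and shows that a change of ring at this place need not cost anything, since the loss seen so far belongs to pyridin-3-yl alone. Nothing at hand accounts for these differences.

The compounds shown leave open whether the hydrogen-bond donor of 1H-pyrazol-3-yl counts for anything at this place, which a pyrazole with a methyl group on its ring nitrogen would test, and whether other five-membered aromatic rings such as imidazole, thiazole or oxazole would behave alike. They also leave open what a plain phenyl ring or a saturated ring such as morpholine would give here.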